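The source may report more compounds than this note shows. Statements on the series, on what has been measured and on what is new or still open speak of the compounds shown alone.

Among the measured compounds shown here, compound 1 `Fc1ccc(CN2CCC(NCCSC(c3ccc(F)cc3)c3ccc(F)cc3)CC2)cc1` is the only compound here with a number attached: in an assay on membranes from HEK293 cells for displacement of a labelled ligand from D(4) dopamine receptor (Homo sapiens), read by scintillation counting, with a stated time of 60 min (on this read-out higher numbers stand for weaker inhibition and lower numbers for stronger inhibition), compound 1 gives 980 nM. Compound 2 `[O-][S+](CCNC1CCN(CC(O)Cc2ccccc2)CC1)C(c1ccc(F)cc1)c1ccc(F)cc1` belongs to the same series, yet for compound 2 the outcome in this assay reads "not determined" (no result reported), so it adds nothing to compare against. For the measured compounds named here, no two measured compounds differ in just one place, so no step size can be read off the data, and the usual scatter is the only yardstick. Compound 3 `O=C(c1ccc(F)cc1)N1CCC(NCCSC(c2ccc(F)cc2)c2ccc(F)cc2)CC1` differs from compound 1 in a single place: (4-fluorophenyl)carbonyl in place of 4-fluorobenzyl on an amine nitrogen in a ring. With this change the ring nitrogen that carries the new group becomes part of an amide rather than a free amine. Without a measured precedent, the step of a 3.6-fold higher number from compound 1 to compound 3 (0.55 log units; beyond the scatter) is expected to run towards weaker inhibition, beyond the scatter. For compound 3 the estimate in this assay is 3500 nM, expected to fall between 900 nM and 14000 nM.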

Compound 3, inhibition constant: 9020 nM
The estimate for compound 3 lay 2.6-fold (0.41 log units) below the measured number; the range from low to high includes it.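

In this assay the swap of 4-fluorobenzyl for (4-fluorophenyl)carbonyl on the ring amine nitrogen gives a 9.2-fold higher number from compound 1 to compound 3 (0.96 log units; beyond the scatter) and so shows that this position responds to what it carries, with the change running towards weaker inhibition. The aromatic ring and its fluorine are present on both sides of the step, while the entering group adds a carbonyl with one hydrogen-bond acceptor. Nothing available gives a reason for the size of this step.

Going by these compounds, whether a simple methyl, a longer chain ending in 4-fluorophenyl or a (4-fluorophenyl)sulfonyl group on this nitrogen would come closer to compound 1 or to compound 3 remains open. Also open, on these data alone, is whether the same swap would give a step of similar size on another core.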